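The compounds below may be only part of what the source reports. "The series", "measured", "known", "first", "only" and "open" are said of these compounds alone.

Compound 1, `O=C(O)c1ccccc1-c1ccccc1C(=O)NCCCCCCCn1cc(-c2cccnc2)nn1`, is the reference point: in an assay for inhibition of Nicotinamide phosphoribosyltransferase (Mus musculus), read by fluorescence, with a stated time of 1 h, in the presence of a further agent that is not named here (on this read-out lower numbers stand for stronger inhibition and higher numbers for weaker inhibition), compound 1 gives 38.5 nM. Compound 2, `O=C(O)c1cccc(-c2ccccc2C(=O)NCCCCCCCn2cc(-c3cccnc3)nn2)c1`, carries a 3-carboxyphenyl where compound 1 carries a 2-carboxyphenyl. For compound 2 this assay reports only a limit, > 500 nM, so compound 2 stands at the weak end of what has been seen here, as the limit of > 500 nM in this assay, at which 1 of the 2 values shown sits, shows. The measured step, an at least 12-fold higher number from compound 1 to compound 2 (1.11 log units; beyond the scatter), is therefore a lower bound on how much the move of the carboxylic acid cost.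

Compound 3, `O=C(O)c1ccc(-c2ccccc2C(=O)NCCCCCCCn2cc(-c3cccnc3)nn2)cc1`, continues along the same ring: 4-carboxyphenyl in place of 3-carboxyphenyl on an aromatic carbon. Going by the values given here, only one measured step bears on this change, and it was large and toward weaker inhibition, so no recovery toward compound 1 is expected. For compound 3 the expected step is a step that the limit leaves unreadable from compound 2 to compound 3, with nothing beyond the scatter anticipated. Compound 3 is estimated at 900 nM, within 250 nM to 5000 nM, and a limit rather than a number is the likelier outcome.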

Compound 3, half-maximal inhibitory concentration: > 500 nM
Compound 3 ended at the assay's limit (the forecaster's own chance of this, stated with the estimate: 60%); the middle value does not contradict the limit.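

Moving the carboxylic acid to the 4-carboxyphenyl gives no recovery in this assay, and the step is an at least 12-fold higher number from compound 1 to compound 3 (1.11 log units; beyond the scatter). Compound 3 gives > 500 nM, which is a limit of the assay and not a number. Among these three compounds, then, the weak result is not confined to the 3-carboxyphenyl, and only the 2-carboxyphenyl of compound 1 gives a readable value, while the other two end at the same limit: the limit of > 500 nM in this assay, at which 2 of the 3 values shown sit.

As far as these compounds go, the step between compound 2 and compound 3 cannot be read, and which of the two is the weaker stays open. Also open, from the compounds shown here alone, is whether a tetrazole or a primary amide in place of the carboxylic acid of the 2-carboxyphenyl, or a shorter chain, would keep the inhibition seen for compound 1.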